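Swapping a Trimethoxyphenyl for a Dichlorophenyl on the Hydrazone

The source may hold more compounds than are shown below. What is called first, only, known or untested is meant among the compounds shown, and "the series" means these compounds.

Among the compounds with values here, compound 1 `CN(C)CCn1cnnc1-c1cc(Oc2ccc(NC(=O)N/N=C/c3cc(C(C)(C)C)cc(C(C)(C)C)c3O)cc2F)ccn1` is the only member of this small set with a number in an ADME assay on WI-38 cells (Homo sapiens) for cytotoxicity, read by MTT assay, with a stated time of 72 h; a higher number here means a weaker inhibitor, a lower number a stronger inhibitor: compound 1 gives 2350 nM. Compound 2 `COc1ccc(/C=N/NC(=O)Nc2ccc(Oc3ccnc(-c4nncn4CCN(C)C)c3)c(F)c2)c(OC)c1OC` shares the same core and differs only at the aromatic ring hanging off the hydrazone; in this assay compound 2 stands at "not determined" (no result reported), so there is no number to lean on. Compound 3 `COc1cc(/C=N/NC(=O)Nc2ccc(Oc3ccnc(-c4nncn4CCN(C)C)c3)c(F)c2)cc(OC)c1OC` is in the same position, with "not determined" (no result reported) in this assay. Compound 4 `CN(C)CCn1cnnc1-c1cc(Oc2ccc(NC(=O)N/N=C/c3cccc(Cl)c3Cl)cc2F)ccn1` has not yet been measured. It differs from compound 2 by one change: 2,3-dichlorophenyl in place of 2,3,4-trimethoxyphenyl on a carbon with a double bond to nitrogen. Within the data shown here, no step between measured compounds exists here, so no direction of change can be read from the data; the only anchor is compound 1. Compound 4 is therefore expected to land near that anchor, at 2500 nM, with a plausible range from 700 nM to 9000 nM, and this expectation rests on compound 1 giving 2350 nM.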

Compound 4, half-maximal inhibitory concentration: 6130 nM
For compound 4 the middle estimate is 2.5-fold (0.39 log units) below the measured one; measured number inside the range.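

Within the data shown here, compound 2 has no single number in this assay, so no step to compound 4 can be read. No measured evidence bears on the result for compound 4. The compounds shown leave open how replacing 2,3,4-trimethoxyphenyl with 2,3-dichlorophenyl alone shifts this read-out.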